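The compounds below may be only part of what the source reports. "The series", "measured", "known", "first", "only" and "open" are said of these compounds alone.

Working notes on the series. In an ADME assay on the whole organism with Oryza sativa as the target, tested at 10 uM (on this read-out lower numbers stand for a stronger effect and higher numbers for a weaker effect at the one concentration tested), compound 1 `Cc1ccc(NC(=O)N[C@@H](C)c2ccccc2)cc1` gives 100%, compound 2 `C[C@@H](NC(=O)Nc1ccc(C(C)(C)C)cc1)c1ccccc1` gives 53%, and compound 3 `C[C@H](NC(=O)Nc1ccc(C(C)(C)C)cc1)c1ccccc1` gives 64%, the second highest of the three numbers. The step from compound 1 to compound 3 is a number 36 percentage points lower from compound 1 to compound 3 (beyond the scatter); the step from compound 2 to compound 3 is a number 11 percentage points higher from compound 2 to compound 3 (beyond the scatter), which rests on (the fact that compounds 2 and 3 differ only in the configuration as drawn). Compound 4 `CCCCCCc1ccc(NC(=O)N[C@@H](C)c2ccccc2)cc1` differs from compound 3 as follows: hexyl in place of tert-butyl on an aromatic carbon. Among the compounds with values here, only the step from compound 1 to compound 3 bears on a change of the group on the aromatic carbon, and it was large, so a further lowering in this assay is expected, but smaller. For compound 4 the expected step is a number 14 percentage points lower from compound 3 to compound 4 (beyond the scatter). Compound 4 is estimated at 50%, with a range of 30% to 75%.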

Compound 4, a percentage reported as activity, at one concentration (the size of the read-out at that concentration, not a potency): 99%
Estimate against measurement, compound 4: 49 percentage points below, outside the stated range (above it).
By their numbers in this assay, from the lowest: compound 2; then compound 3; then compounds 4 and 1 (each within the scatter of the next).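

At this position on the aromatic carbon, more carbon in the group does not carry the lowering further: in this assay hexyl in place of tert-butyl gives a number 35 percentage points higher from compound 3 to compound 4 (beyond the scatter). Against the methyl group the hexyl chain gives a number 1 percentage points lower from compound 1 to compound 4 (within the scatter), so among these groups only tert-butyl separates from the rest. Nothing on hand accounts for this reversal.

Open, from the compounds shown here alone, is whether the lowering needs branching at this position: an isopropyl group or a butyl chain would bear on that. Also open, going by these compounds, is how a methoxy group would compare.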